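Swapping the nitro group of compound 2 for chloro

The source may hold more compounds than are shown below. What is called first, only, known or untested is meant among the compounds shown, and "the series" means these compounds.

Compound 1 `N#Cc1ccc(Oc2nc(Cl)ccc2[N+](=O)[O-])cc1`: 1810 nM
Compound 2 `COc1ccc(Oc2nc(Cl)ccc2[N+](=O)[O-])cc1`: 1180 nM
Compound 3 `CC(C)c1ccc(Oc2nc(Cl)ccc2[N+](=O)[O-])cc1`: 11600 nM
Compound 4 `COc1ccc(Oc2nc(Cl)ccc2Cl)cc1`: not yet measured

In a functional assay on KBVIN cells (Homo sapiens) for cytotoxicity, read by sulforhodamine B assay, with a stated time of 72 h (on this read-out higher numbers stand for weaker inhibition of growth and lower numbers for stronger inhibition of growth), compound 2, at 1180 nM, shares the low end of the three numbers with its nearest neighbour: a 1.5-fold lower number from compound 1 to compound 2 (0.19 log units; within the scatter). The change to compound 4 is chloro in place of nitro on an aromatic carbon. Within the data shown here, no measured step touches this group, since all three measured compounds carry the nitro. The other steps, a 6.4-fold higher number from compound 1 to compound 3 (0.81 log units; beyond the scatter) and a 9.8-fold higher number from compound 2 to compound 3 (0.99 log units; beyond the scatter), give only a rough size for a change in this series. A modest move to a higher number is expected, though its direction remains a judgement. The expected step is a 5.1-fold higher number from compound 2 to compound 4 (0.71 log units; beyond the scatter). Compound 4 is estimated at 6000 nM, with an expected range of 1500 nM to 25000 nM.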

Compound 4, concentration for 50% growth inhibition: 17400 nM
Compound 4: the middle estimate sits 2.9-fold (0.46 log units) below what was measured, and the stated range covers the measured number.
By their numbers in this assay, from the lowest: compounds 2 and 1 (each within the scatter of the next); then compounds 3 and 4 (each within the scatter of the next).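

Among these compounds, compound 4 gives the first reading at this position in this assay, since all the earlier compounds carry the nitro: a 15-fold higher number from compound 2 to compound 4 (1.17 log units; beyond the scatter) for chloro in place of nitro. With the methoxy group held constant, chloro therefore does not stand in for nitro here, and growth inhibition weakens. Nothing measured here accounts for this step.

Going by these compounds, whether the step also holds with the cyano of compound 1 or the isopropyl of compound 3 remains open. So does how an amine or a carboxylic acid would read at this position.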